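One Double Bond Drawn Z Instead of E

A few compounds are considered here, and "the series" means these few. Any claim that something is new, unique, unknown or untested is made for them only; others in the source may bear on it.

In a functional assay on DU-145 cells (Homo sapiens) for antiproliferative activity, read by WST assay, with a stated time of 72 h (on this read-out higher numbers stand for an effect only at larger amounts of compound and lower numbers for an effect already at smaller amounts), compound 1 `CCCCCCCC/C=C\c1c(C)c(/C=C\CCCCCCCC)c2[n+](c1C)CCC2` gives 1 uM, compound 2 `CCCCCCCC/C=C/c1c(C)c(/C=C/CCCCCCCC)c2[n+](c1C)CCC2` gives 0.8 uM and compound 3 `CCCCCCCCCCc1c(C)cc2[n+](c1C)CCC2` gives 1.6 uM. Compound 2 thus lies within the usual scatter of both other compounds. Compound 4 `CCCCCCCC/C=C\c1c(C)c(/C=C/CCCCCCCC)c(C)[n+]2c1CCC2` relates to compound 2 as follows: the two compounds have the same atoms and bonds and differ only in configuration as drawn: 1 of 2 stereo elements differ; a double bond is drawn E in compound 2 and Z in compound 4. For the measured compounds named here, the one measured step that bears on this change is a 1.3-fold lower number from compound 1 to compound 2 (0.10 log units; within the scatter), and it rests on (the fact that compounds 1 and 2 differ only in the configuration as drawn). That step reversed both double bonds, while only one differs here, so no step beyond the scatter is expected in either direction. The expected change is a 1.1-fold higher number from compound 2 to compound 4 (0.05 log units; within the scatter). Compound 4 is estimated at 0.9 uM, with an expected range from 0.45 uM to 1.8 uM.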

Compound 4, concentration for half-maximal effect: 0.8 uM
Compound 4: the middle estimate sits 1.1-fold (0.05 log units) above what was measured, and the stated range covers the measured number.
By their numbers in this assay, from the lowest: compounds 2, 4, 1 and 3 (each within the scatter of the next).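

For the compounds shown here, compound 4 carries one E and one Z double bond, so for the first time a single double bond changes on its own, where the step between compound 1 and compound 2 changed both together. In this assay the E to Z change at one double bond gives no change at the digits printed from compound 2 to compound 4 (within the scatter), and the Z to E change at the other gives a 1.3-fold lower number from compound 1 to compound 4 (0.10 log units; within the scatter), so neither single change leaves the scatter. All three configurational forms thus read alike.

From the compounds shown here alone, how the swapped arrangement of the E and Z double bonds would read remains open. So does the effect of a longer chain, or of an amine or a carboxylic acid at the chain end.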